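The source may report more compounds than this note shows. Statements on the series, on what has been measured and on what is new or still open speak of the compounds shown alone.

Measured in an in vitro ADME assay on microsomes from liver (Homo sapiens) for metabolic stability, read by HPLC; a higher number here means faster removal of the compound, a lower number slower removal:
- compound 1 `CC1(C)C[C@H](CN([C@H](CCC(F)(F)F)C(N)=O)S(=O)(=O)c2ccc(Cl)cc2)O1` gives 29 mL/min/kg
- compound 2 `NC(=O)[C@@H](CCC(F)(F)F)N(C[C@H]1CCCOC1)S(=O)(=O)c1ccc(Cl)cc1` gives 156 mL/min/kg

Going by the values given here, compound 2 holds the higher of the two numbers, and compound 1 is its only neighbour. The next structure is compound 3 `NC(=O)[C@@H](CCC(F)(F)F)N(C[C@H]1COCCO1)S(=O)(=O)c1ccc(Cl)cc1`, still unmeasured, which differs from compound 2 by 1,4-dioxan-2-yl in place of oxan-3-yl on a saturated chain carbon bound to a sulfonamide nitrogen. In short, 1,4-dioxan-2-yl stands in place of oxan-3-yl on a saturated chain carbon bound to a sulfonamide nitrogen.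

Among the compounds with values here, one measured step bears on this change, at the same place: a 5.4-fold higher number from compound 1 to compound 2 (0.73 log units; beyond the scatter). Within the data shown here, it involves a different group swap, and no measured compound carries 1,4-dioxan-2-yl, so it guides size only, and loosely. Compound 2 at 156 mL/min/kg sits at the top of a very small set, so a fall smaller than that step is expected. The expected change is a 2.2-fold lower number from compound 2 to compound 3 (0.35 log units; beyond the scatter). For compound 3 the estimated value is 70 mL/min/kg, with an expected range of 35 mL/min/kg to 140 mL/min/kg.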

Compound 3, clearance: 176 mL/min/kg
Compound 3: the middle estimate sits 2.5-fold (0.40 log units) below what was measured, and the stated range ends below it.
By their numbers in this assay, from the lowest: compound 1; then compounds 2 and 3 (each within the scatter of the next).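

Placing a second ring oxygen at this position, with 1,4-dioxan-2-yl in place of oxan-3-yl on a saturated chain carbon bound to a sulfonamide nitrogen, leaves no readable difference in this assay (a 1.1-fold higher number from compound 2 to compound 3 (0.05 log units; within the scatter)). The gap to the 4,4-dimethyloxetan-2-yl compound now holds for two six-membered rings rather than one (a 6.1-fold higher number from compound 1 to compound 3 (0.78 log units; beyond the scatter)), so within these three compounds it does not depend on the oxan-3-yl group alone. No measurement is available here that would explain these numbers.

Going by these compounds, it remains open whether the gap goes with the oxetane ring or with its two methyl groups, a question that an unsubstituted oxetan-2-yl group would address. On these data alone, how a ring nitrogen, as in morpholin-2-yl, would read at this position also remains open.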